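The compounds below may be only part of what the source reports. "The series", "measured", "known", "first", "only" and "open" are said of these compounds alone.

Working notes on the series. In a toxicity assay on MT2 cells (Homo sapiens) for cytotoxicity (on this read-out lower numbers stand for higher toxicity in this test and higher numbers for lower toxicity in this test), compound 1 (`Cc1nc(C)c([C@H](OC(C)(C)C)C(=O)O)c(N2CCC(C)(C)CC2)c1-c1ccc2c(c1)CCN(Cc1cccc(F)c1F)C2`) gives >= 24000 nM, which is a limit and not a number. Compound 2 (`Cc1nc(C)c([C@H](OC(C)(C)C)C(=O)O)c(N2CCC(C)(C)CC2)c1-c1ccc2c(c1)CCN(Cc1ccc(F)cc1F)C2`) gives >= 24000 nM, and this too is only a limit. Both compounds therefore stand at the limit of >= 24000 nM in this assay, at which 2 of the 2 values shown sit, and compound 2 has no exact position in this assay.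

The next change leads to compound 3 (`Cc1nc(C)c([C@H](OC(C)(C)C)C(=O)O)c(N2CCC(C)(C)CC2)c1-c1ccc2c(c1)CCN(c1ncnc3c1cnn3C)C2`), which remains to be measured. The difference is a group of 10 heavy atoms (6 carbon, 4 nitrogen; one five-membered aromatic ring with 2 hetero atoms, one six-membered aromatic ring with 2 hetero atoms) in place of a group of 9 heavy atoms (7 carbon, 2 fluorine; one six-membered aromatic ring of carbon only), on an amine nitrogen in a ring. The change replaces the 2,4-difluorobenzyl on an amine nitrogen in a ring.

Among the compounds with values here, only one measured step bears on this change, and it concerns a much smaller edit at the same region: a step that the two limits leave unreadable from compound 1 to compound 2. Within the data shown here, that step has no size to carry over, and no measured step shows what a swap of this kind does. In this assay, no step beyond the scatter is therefore expected, and no direction can be assigned with any confidence. The expected step is an at least 1.2-fold lower number from compound 2 to compound 3 (0.07 log units; that floor lies within the scatter). A further reading that is only a limit is also considered likely. For compound 3 the estimate is 20000 nM, with an expected range from 8000 nM to 45000 nM.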

Compound 3, half-maximal cytotoxic concentration: >= 17000 nM
Compound 3: a limit, no number; the forecaster's own chance of this, stated with the estimate: 65%; the middle value does not contradict the limit.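

In this assay compound 3 gives >= 17000 nM, which is a limit and not a number. Within the data shown here, with compound 1, compound 2 and compound 3 all reported only as limits, no step among them can be read. Still open, as far as these compounds go, is where each compound's actual value lies, and whether the group on the amine nitrogen in a ring affects this read-out at all.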